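The source may hold more compounds than are shown below. What is called first, only, known or untested is meant among the compounds shown, and "the series" means these compounds.

The study centres on compound 1 `Cc1nc(N)c2nc(-c3ccccc3)sc2n1` and asks what happens when its ring amine is capped. In a functional assay on CHO cells for antagonist activity at adenosine receptor A2b (Homo sapiens), read by cAMP accumulation, with a stated time of 10 min (on this read-out higher numbers stand for weaker inhibition and lower numbers for stronger inhibition), compound 1 gives only a limit, > 30000 nM. Its one measured relative, compound 2 `Nc1nc(-c2ccccc2)nc2sc(-c3ccccc3)nc12`, carries phenyl in place of methyl on an aromatic carbon. In this assay compound 2 likewise reaches only a limit, > 30000 nM. The step from compound 1 to compound 2 is therefore a step that the two limits leave unreadable from compound 1 to compound 2; both values sit at the limit of > 30000 nM in this assay, at which 2 of the 2 values shown sit, so neither the direction nor the size of that change can be read. Compound 3 `Cc1nc(NC(=O)c2ccccc2)c2nc(-c3ccccc3)sc2n1` is the unmeasured target, differing from compound 1 by benzoyl in place of hydrogen on a nitrogen on an aromatic ring. Among the measured compounds shown here, no measured step touches this nitrogen, and the only step recorded is unreadable, so no size of step in this assay can be forecast from the numbers in hand; compound 3 may well also report only a limit. Compound 3 is expected to give about 15000 nM in this assay, ranging from 2000 nM to 100000 nM. The estimated step is an at least 2.0-fold lower number from compound 1 to compound 3 (0.30 log units; that floor lies within the scatter).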

Compound 3, half-maximal inhibitory concentration: > 30000 nM
Compound 3: a limit, no number; the forecaster's own chance of this, stated with the estimate: 55%; middle value at least 2.0-fold (0.30 log units) away from the limit.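

In this assay compound 3 reports only a limit, as compound 1 does, so the change from compound 1 to compound 3 cannot be read: the limit of > 30000 nM in this assay, at which 3 of the 3 values shown sit.

The compounds shown leave open whether benzoyl in place of hydrogen on a nitrogen on an aromatic ring alters inhibition in either direction, and how compound 1, compound 2 and compound 3 rank.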